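Trading Methoxy for Chloro on the Shared Core

This account rests on a few compounds, and the source may have more. Where it says the series, first, only, none or still open, it means among the compounds named here.

Compound 1 `COc1ccc(C2CC(C3C(=O)c4ccccc4C3=O)=NC(=O)N2)cc1` was tested in a functional assay on the whole organism for inhibition, with Rattus norvegicus as the target, read by paw edema, with stated times of 30 min and 4 h, at a dose of 10 mg/kg by the oral route (on this read-out higher numbers stand for more inhibition at the one dose given (going by the name of the read-out) and lower numbers for less inhibition), where compound 1 gives 10%. Its only measured relative, compound 2 `O=C1N=C(C2C(=O)c3ccccc3C2=O)CC(/C=C/c2ccccc2)N1`, gives 16%; the change a number 6 percentage points higher from compound 1 to compound 2 (within the scatter) lies within the scatter, so compound 1 holds the lower of the two numbers yet cannot be told apart from compound 2. Compound 3 `O=C1N=C(C2C(=O)c3ccccc3C2=O)CC(c2ccc(Cl)cc2)N1` differs from compound 1 by chloro in place of methoxy on an aromatic carbon. For the measured compounds named here, no measured step covers this exchange, and the one step that exists, swapping the whole aryl group, was itself small. For compound 3 a step of a number 2 percentage points higher from compound 1 to compound 3 (within the scatter) is expected, not beyond the scatter. Compound 3 is estimated at 12%, within 0% to 30%.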

Compound 3, a percentage reported as inhibition, in the whole organism at one dose (the size of the read-out at that dose, not a potency): 34%
Estimate against measurement, compound 3: 22 percentage points below; the whole stated range lies below it.
By their numbers in this assay, from the lowest: compounds 1 and 2 (each within the scatter of the next); then compound 3.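

In this assay, the group on the aromatic ring proves able to shift the read-out: chloro in place of methoxy, para to a large group, gives a number 24 percentage points higher from compound 1 to compound 3 (beyond the scatter) and so moves the number clear of the scatter. Against the other relative, 4-chlorophenyl in place of 2-phenylethenyl gives a number 18 percentage points higher from compound 2 to compound 3 (beyond the scatter), so compound 3 stands apart from both earlier compounds, which could not be told apart from each other.

Going by these compounds, whether this gain is special to chloro remains open, and fluoro, methyl or an amine at the same place would test that. Nothing measured here offers a reason for the gain.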